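Two Fluorines in Place of Two Chlorines

The compounds below may be only part of what the source reports. "The series", "measured", "known", "first", "only" and "open" are said of these compounds alone.

Measured so far in a functional assay on SW-620 cells (Homo sapiens) for cytotoxicity, read by sulforhodamine B assay, with a stated time of 48 h, tested at 0.1 uM; a lower number here means a stronger effect, a higher number a weaker effect of the compound at the concentration tested:
- compound 1 `COc1cc(-c2cc(/C=C/C(=O)c3ccc(Cl)c(Cl)c3)[nH]n2)cc(OC)c1OC` gives 99%
- compound 2 `COc1ccc(-c2cc(/C=C/C(=O)c3ccc(N)cc3)[nH]n2)cc1OC` gives 97%
- compound 3 `COc1ccc(-c2cc(/C=C/C(=O)c3ccc(N)cc3)[nH]n2)cc1` gives 101%

All three numbers sit close to one another. Compound 1 lies between the other two, with compound 2 and compound 3 each within the usual scatter of it, so none of the three can be told apart by this assay. For the measured compounds named here, the only measured step, a number 4 percentage points higher from compound 2 to compound 3 (within the scatter), is also within the scatter.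

Compound 4 `COc1cc(-c2cc(/C=C/C(=O)c3ccc(F)c(F)c3)[nH]n2)cc(OC)c1OC` differs from compound 1 in one place: 3,4-difluorophenyl in place of 3,4-dichlorophenyl on a carbonyl carbon. Going by the values given here, no measured step touches this part of the molecule; the one step on record concerns a methoxy group on a different ring and shows no movement. The three measured compounds, with quite different groups on the aromatic ring attached to the carbonyl carbon, all give numbers near the top of the range in this assay.

On that basis no step beyond the scatter is expected, no change at the digits printed from compound 1 to compound 4 (within the scatter). For compound 4 the estimate is 99%, with a range from 90% to 106%.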

Compound 4, a percentage reported as activity, at one concentration (the size of the read-out at that concentration, not a potency): 97%
For compound 4 the middle estimate is 2 percentage points above the measured one, and the stated range covers the measured number.
By their numbers in this assay, from the lowest: compounds 2, 4, 1 and 3 (each within the scatter of the next).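

Replacing 3,4-dichlorophenyl with 3,4-difluorophenyl on a carbonyl carbon gives a number 2 percentage points lower from compound 1 to compound 4 (within the scatter) in this assay. For the compounds shown here, this is the first direct comparison at this position, as the only earlier step concerned a methoxy group on a different ring, and it shows that this exchange of one halogen pair for another leaves the two compounds indistinguishable at the concentration tested. No measurement is available that could explain this result.

Going by these compounds, it remains open whether compound 1 and compound 4 would separate at a higher concentration, where a single reading at one low concentration offers no guide. Also open, on these data alone, is whether a carboxylic acid or a nitrile on this ring, in place of the two halogens, would give a number beyond the scatter.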